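This account rests on a few compounds, and the source may have more. Where it says the series, first, only, none or still open, it means among the compounds named here.

Compound 1, `CCCCCCOc1ccc(-n2cnnc2)cc1`, carries a hydrogen on the aromatic carbon of its five-membered ring that is later varied, and in a functional assay on the whole organism (strain C57B/6) with Mus musculus as the target, in the maximal electroshock model (on this read-out lower numbers stand for an effect already at smaller amounts and higher numbers for an effect only at larger amounts of compound), compound 1 gives 9.8 mg/kg. Compound 2, `CCCCCCOc1ccc(-n2cnnc2CC)cc1`, bears an ethyl there and in this assay compound 2 gives 13.2 mg/kg, the higher of the two plain numbers, its nearest neighbour being compound 1 at a gap that lies within the scatter, as the step of a 1.3-fold higher number from compound 1 to compound 2 (0.13 log units; within the scatter) shows. Compound 3, `CCCCCCOc1ccc(-n2cnnc2CCCCCC)cc1`, carries a hexyl on that carbon; in this assay compound 3 reaches only a limit, > 40 mg/kg, so its number is not known, and the limit of > 40 mg/kg in this assay, at which 1 of the 3 values shown sits, is where this value sits. The step of an at least 4.0-fold higher number from compound 1 to compound 3 (0.61 log units; beyond the scatter) and the step of an at least 3.0-fold higher number from compound 2 to compound 3 (0.48 log units; beyond the scatter) both point the same way: a larger group on this carbon goes with a higher number.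

Compound 4, `CCCCCCOc1ccc(-n2cnnc2-c2ccccc2Cl)cc1`, is compound 2 with 2-chlorophenyl in place of ethyl on an aromatic carbon. The entering group is larger than the ethyl it replaces and of a size nearer the hexyl of compound 3, so the steps toward compound 3 are the ones that bear on it. Compound 4 is therefore expected to show a step of a 2.3-fold higher number from compound 2 to compound 4 (0.36 log units; beyond the scatter) in this assay, toward a higher number. The estimate for compound 4 is 30 mg/kg, with a range from 12 mg/kg to 80 mg/kg.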

Compound 4, dose for half-maximal effect: 13.2 mg/kg
For compound 4 the middle estimate is 2.3-fold (0.36 log units) above the measured one, and the stated range covers the measured number.
By their numbers in this assay, from the lowest: compounds 1, 2 and 4 (each within the scatter of the next). At a limit, above all of these: compound 3.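

In this assay, a large group on this aromatic carbon does not by itself go with a higher number: 2-chlorophenyl, with its 7 heavy atoms and one six-membered aromatic ring, replaces ethyl with no change at the digits printed from compound 2 to compound 4 (within the scatter), and replaces hydrogen with a 1.3-fold higher number from compound 1 to compound 4 (0.13 log units; within the scatter). Set against the open chain of similar size, the same group gives an at least 3.0-fold lower number from compound 3 to compound 4 (0.48 log units; beyond the scatter), so the link between a larger group and a higher number seen across compound 1, compound 2 and compound 3 does not extend to compound 4, which goes against it and suggests that the kind of group matters here as well as its size. That last comparison remains open-ended, as compound 3 has a limit and not a number: the limit of > 40 mg/kg in this assay, at which 1 of the 4 values shown sits.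

The compounds shown leave open whether the aromatic ring or its chlorine goes with the number of compound 4, a question that a plain phenyl or a pyridine on this carbon would bear on. They also leave open how an amine or a carboxylic acid on this carbon would read in this assay.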